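The source may hold more compounds than are shown below. What is called first, only, known or untested is meant among the compounds shown, and "the series" means these compounds.

Measured so far in a functional assay on DU-145 cells (Homo sapiens) for cytotoxicity, read by MTT assay, with a stated time of 72 h; on this read-out higher numbers stand for an effect only at larger amounts of compound and lower numbers for an effect already at smaller amounts:
compound 1 `COc1ccc(Nc2cc(C3CCCCC3)oc(=O)c2)cc1` — 8.61 uM
compound 2 `O=c1cc(Nc2ccccc2)cc(-c2ccccc2)o1` — 0.098 uM
compound 3 `COc1ccc(Nc2cc(-c3ccc4ccccc4c3)oc(=O)c2)cc1` — 0.15 uM

Compound 1 stands at the highest of the three numbers. In this assay compound 1 gives 8.61 uM, while compound 3 gives 0.15 uM and compound 2 gives 0.098 uM; both gaps to compound 1 lie beyond the usual scatter. Within the data shown here, compounds 2 and 3 differ from compound 1 in more than one place, so no single step between measured compounds is available.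

The next compound, compound 4 `COc1ccc(Nc2cc(-c3ccco3)oc(=O)c2)cc1`, keeps the core of compound 1 and its methoxy-bearing aniline and changes only the group next to the ring oxygen: furan-2-yl in place of cyclohexyl on an aromatic carbon. Since the two measured compounds carrying a ring with aromatic character at this position both sit far below compound 1, the number for compound 4 is expected to fall rather than rise, by more than the scatter. The step expected is a 17-fold lower number from compound 1 to compound 4 (1.24 log units; beyond the scatter). For compound 4 the estimate in this assay is 0.5 uM, with a likely range from 0.1 uM to 2.5 uM.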

Compound 4, concentration for half-maximal effect: 1.95 uM
The estimate for compound 4 lay 3.9-fold (0.59 log units) below the measured number; low and high end bracket the measured number.
By their numbers in this assay, from the lowest: compounds 2 and 3 (each within the scatter of the next); then compound 4; then compound 1.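

Among these compounds, the first one-place step at this position, next to the ring oxygen, is furan-2-yl in place of cyclohexyl with the methoxy-bearing aniline held constant, and in this assay it gives a 4.4-fold lower number from compound 1 to compound 4 (0.64 log units; beyond the scatter), so this group alone moves the number beyond the scatter, though only modestly. An aromatic ring here does not by itself bring the number down to the lowest level seen: compound 3 gives 0.15 uM, whereas compound 4 gives 1.95 uM. Nothing at hand accounts for the size of this step.

Among the compounds shown here, the single step cannot separate ring aromaticity from ring size or from the ring oxygen of the furan-2-yl group. Going by these compounds, how a thiophen-2-yl group or an open butyl chain at this position would compare remains open.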